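This account rests on a few compounds, and the source may have more. Where it says the series, first, only, none or still open, it means among the compounds named here.

Measured compounds:
- compound 1 `O=C(OCc1cccc(Oc2ccccc2)c1)c1cccc(=O)[nH]1`: > 150 nM
- compound 2 `O=C(OCc1cccc(C(F)(F)F)c1)c1cccc(S)n1`: 126000 nM

Both values come from an assay on isolated protein for inhibition of matrix metalloproteinase-9 (Homo sapiens); on this read-out higher numbers stand for weaker inhibition and lower numbers for stronger inhibition. The value of compound 1 is a limit of the assay, not a number. Compound 1 sits at the limit of > 150 nM in this assay, at which 1 of the 2 values shown sits. For the measured compounds named here, compound 2 is therefore the only compound with a number in this assay, and its 126000 nM is the sole anchor. Going by the values given here, no pair of measured compounds differs in one place, so no measured step exists.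

Compound 3 `O=C(OCc1cccc(C(F)(F)F)c1)c1cccc(=O)[nH]1` is not yet measured. It differs from compound 2 by a group of 7 heavy atoms (5 carbon, 1 nitrogen, 1 oxygen; one six-membered aromatic ring with 1 hetero atom) in place of a group of 7 heavy atoms (5 carbon, 1 nitrogen, 1 sulfur; one six-membered aromatic ring with 1 hetero atom), on a carbonyl carbon. The benzylic ester part is unchanged.

Among the compounds with values here, with no measured step of this kind, the size of the expected step in this assay is uncertain; a gain of a 4.2-fold lower number from compound 2 to compound 3 (0.62 log units; beyond the scatter) from compound 2 is the working expectation, with a direction towards stronger inhibition but a wide spread. Compound 3 is expected to give about 30000 nM, within 4000 nM to 150000 nM.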

Compound 3, half-maximal inhibitory concentration: > 150 nM
Compound 3: no number, only a limit; the forecaster's own chance of this, stated with the estimate: 25%; the middle value is on the limit's open side.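

No new step can be read: compound 1 and compound 3 each carry a limit of the assay rather than a number, so the steps from compound 2 to compound 3 and from compound 1 to compound 3 stay unreadable: the limit of > 150 nM in this assay, at which 2 of the 3 values shown sit.

Open remains where compound 1 and compound 3 lie in this assay, and so whether either change in structure shifts inhibition at all.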